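A few compounds are considered here, and "the series" means these few. Any claim that something is new, unique, unknown or untested is made for them only; others in the source may bear on it.

In a functional assay on DMS-114 cells (Homo sapiens) for inhibition, read by sulforhodamine B assay, with a stated time of 48 h (a lower number here means a stronger inhibitor of growth, a higher number a weaker inhibitor of growth), compound 1 `CCCCCCCCCCCC[C@@H](O)[C@H]1CC[C@H]([C@H](O)CCCCCCCCCCNC(=O)c2ccnn2C)O1` gives 10 nM, compound 2 `CCCCCCCCCCCC[C@@H](O)[C@H]1CC[C@H]([C@H](O)CCCCCCCCCCN(C)C(=O)c2ccnn2C)O1` gives 34.7 nM and compound 3 `CCCCCCCCCCCC[C@@H](O)[C@H]1CC[C@H]([C@H](O)CCCCCCCCCCNCc2ccnn2C)O1` gives 129 nM, the highest of the three numbers. Compound 4 `CCCCCCCCCCCC[C@@H](O)[C@H]1CC[C@H]([C@H](O)CCCCCCCCCCC(=O)Nc2ccnn2C)O1` has no reading yet. It carries (1-methyl-1H-pyrazol-5-yl)carbamoyl in place of ((1-methyl-1H-pyrazol-5-yl)methyl)amino on a saturated chain carbon, ten or more bonds along the chain from an oxygen on a saturated carbon and a saturated ring carbon. Among the compounds with values here, two steps bear most directly on this change, the large 13-fold higher number from compound 1 to compound 3 (1.11 log units; beyond the scatter) and the modest 3.7-fold higher number from compound 2 to compound 3 (0.57 log units; beyond the scatter), both ending at the only measured compound without a carbonyl. The modest 3.5-fold higher number from compound 1 to compound 2 (0.54 log units; beyond the scatter) shows that the amide hydrogen also counts. Within the data shown here, no measured compound carries the carbamoyl group itself, so a modest to large drop is expected in this assay, with a 4.3-fold lower number from compound 3 to compound 4 (0.63 log units; beyond the scatter) as the expected step. For compound 4 the estimate is 30 nM, with an expected range of 8 nM to 110 nM.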

Compound 4, concentration for 50% growth inhibition: 3310 nM
Compound 4: the middle estimate sits 110-fold (2.04 log units) below what was measured; the measured number lies above the stated range.
By their numbers in this assay, from the lowest: compound 1; then compound 2; then compound 3; then compound 4.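

Keeping a carbonyl in the linkage does not by itself preserve growth inhibition in this assay: replacing ((1-methyl-1H-pyrazol-5-yl)methyl)amino with (1-methyl-1H-pyrazol-5-yl)carbamoyl gives a 26-fold higher number from compound 3 to compound 4 (1.41 log units; beyond the scatter) and so falls behind the compound without a carbonyl. The loss is wider against the amides in which the nitrogen rather than the carbonyl is attached to the chain, with a 95-fold higher number from compound 2 to compound 4 (1.98 log units; beyond the scatter) and a 330-fold higher number from compound 1 to compound 4 (2.52 log units; beyond the scatter), so the orientation of the amide matters strongly in these compounds. No evidence here bears on the reason for this loss.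

Going by these compounds, whether a methyl on the carbamoyl nitrogen changes the reading of compound 4 remains open. So does whether a urea or a sulfonamide at this place would read closer to compound 1 or to compound 4.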